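Extending the allyl ether: chlorophenyl analog of compound 1

A few compounds are considered here, and "the series" means these few. Any claim that something is new, unique, unknown or untested is made for them only; others in the source may bear on it.

Measured:
compound 1 `C=CCOc1cc(/C=C\c2cc(OC)c(OC)c(OC)c2)ccc1OC` — 12000 nM
compound 2 `COc1ccc(/C=C\c2cc(OC)c(OC)c(OC)c2)cc1OCCC/C=C/c1ccc(F)cc1` — 16000 nM

In a functional assay on MCF7 cells (Homo sapiens) for inhibition, read by MTT assay, with a stated time of 3 days (on this read-out higher numbers stand for weaker inhibition and lower numbers for stronger inhibition), compound 1 gives 12000 nM, the lowest of the two numbers shown, and compound 2 gives 16000 nM. The step of a 1.3-fold higher number from compound 1 to compound 2 (0.12 log units; within the scatter) is the only one bearing on the next change. Compound 3 `COc1ccc(/C=C\c2cc(OC)c(OC)c(OC)c2)cc1OCCC/C=C/c1ccc(Cl)cc1` differs from compound 1 by 4-(4-chlorophenyl)but-3-en-1-yl in place of vinyl on a saturated chain carbon bound to an oxygen on an aromatic ring. The measured step of a 1.3-fold higher number from compound 1 to compound 2 (0.12 log units; within the scatter) stays within the scatter, so no step beyond the scatter is expected here either; the expected step is a 1.3-fold higher number from compound 1 to compound 3 (0.10 log units; within the scatter). Compound 3 is estimated at 15000 nM, with a range from 6000 nM to 40000 nM.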

Compound 3, half-maximal inhibitory concentration: 40000 nM
Estimate against measurement, compound 3: 2.7-fold (0.43 log units) below, within the range that was stated.
By their numbers in this assay, from the lowest: compounds 1 and 2 (each within the scatter of the next); then compound 3.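

In this assay the 4-(4-chlorophenyl)but-3-en-1-yl group gives a 3.3-fold higher number from compound 1 to compound 3 (0.52 log units; beyond the scatter) and so weakens inhibition at this place, on a saturated chain carbon bound to an oxygen on an aromatic ring, which compound 2 did not show. Chloro in place of fluoro on an aromatic carbon gives a 2.5-fold higher number from compound 2 to compound 3 (0.40 log units; beyond the scatter) and shows that the halogen alone changes the number beyond the scatter. Nothing available explains either step.

On these data alone, whether a methoxy group or an amine at that aromatic carbon would keep or reverse this loss remains open. As far as these compounds go, the effect of a longer chain also remains open.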